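Acetyl for Methyl on the Shared Core: a Lipophilicity Estimate

The source may hold more compounds than are shown below. What is called first, only, known or untested is meant among the compounds shown, and "the series" means these compounds.

Measured so far:
Compound 1, `c1ccc2c(-c3cn4ccnc4c(-c4ccc5ncn(C6CCCCC6)c5c4)n3)cccc2c1`, gives 1.44 in a physicochemical assay for lipophilicity, using the shake flask method, in phosphate buffer, measured as octanol-water partition, with a stated time of 85 min, at pH 7.4; a lower number here means a more polar compound, a higher number a more lipophilic compound.
Compound 2, `Cc1cccc(-c2cn3ccnc3c(-c3ccc4ncn(C5CCCCC5)c4c3)n2)c1`, gives 1.87 in this assay.

Within the data shown here, only two compounds have been measured, and compound 2 holds the higher of the two numbers; its nearest neighbour is compound 1, and the step of a number 0.43 log units higher from compound 1 to compound 2 (beyond the scatter) is a modest one that lies beyond the usual scatter. That step exchanges a naphthalen-1-yl group for a 3-methylphenyl group on the shared core.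

Compound 3, `CC(=O)c1ccc(-c2cn3ccnc3c(-c3ccc4ncn(C5CCCCC5)c4c3)n2)cc1`, has not yet been measured. It differs from compound 2 in one place: 4-acetylphenyl in place of 3-methylphenyl on an aromatic carbon. Among the measured compounds shown here, no measured step exchanges a methyl-bearing ring for an acetyl-bearing one, so the single step from compound 1 to compound 2 bears on it only loosely, as a guide to how much this assay moves when the pendant ring is changed. The entering group carries one hydrogen-bond acceptor where the leaving group carries none. On that basis compound 3 is expected to give 1.2 in this assay, within the range 0.7 to 1.7. The expected step from compound 2 is a number 0.67 log units lower from compound 2 to compound 3 (beyond the scatter), downward and beyond the scatter.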

Compound 3, partition coefficient: 2.06
The estimate for compound 3 lay 0.86 log units below the measured number; measured number above the stated range.
By their numbers in this assay, from the lowest: compound 1; then compounds 2 and 3 (each within the scatter of the next).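

In this assay, putting 4-acetylphenyl in place of 3-methylphenyl on this aromatic carbon of the shared core gives a number 0.19 log units higher from compound 2 to compound 3 (within the scatter). At this position, then, a larger group carrying a hydrogen-bond acceptor can enter where the leaving group has none, and the two compounds still cannot be told apart in this measurement. The other new comparison, with naphthalen-1-yl at the same place, gives a number 0.62 log units higher from compound 1 to compound 3 (beyond the scatter), so this second replacement of that group also clears the scatter; nothing available here accounts for either step.

The change from compound 2 to compound 3 alters both the group on the phenyl ring and its place on that ring, so these compounds cannot show what either alteration does alone, and the small step could hide two separate effects that offset each other. They also leave open whether an amine or a carboxylic acid on the phenyl ring at this position would shift the number beyond the scatter from compound 2, which neither the methyl nor the acetyl group does here.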